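The source may hold more compounds than are shown below. What is called first, only, known or untested is meant among the compounds shown, and "the series" means these compounds.

Of the compounds shown here, three have so far been tested in a toxicity assay on the whole organism (strain CD-1) for cytotoxicity, with Mus musculus as the target, with a stated time of 14 days, at a dose of 50 mg/kg by the intraperitoneal route; on this read-out higher numbers stand for a weaker effect at the one dose given and lower numbers for a stronger effect. Compound 1 `COc1c(C(=O)O)cc(F)c(F)c1F` gives 100% in this assay. Compound 2 `COC(=O)c1c(O)c(F)c(F)c(F)c1F` gives 100%. Compound 3 `CC(=O)Oc1c(F)c(F)c(F)c(F)c1C(=O)O` gives 100%. On these numbers compound 3 stands level with compound 1 and compound 2; the gaps between the three are within the usual scatter of repeated measurements, so none of them can be called stronger or weaker than another in this assay.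

Compound 4 `CC(=O)Oc1c(C(=O)O)cc(F)c(F)c1F` has not yet been measured. It differs from compound 3 in one place: hydrogen in place of fluoro on an aromatic carbon. The change is small, a single fluorine atom giving way to a hydrogen atom on an aromatic carbon, while the carboxy group and the acetoxy group are kept.

Going by the values given here, no step between two measured compounds is available to show what such a change does in this assay. What can be said is that the three measured compounds, which carry different groups on the shared core, all give the same read-out. For compound 4 the expected step is therefore no change at the digits printed from compound 3 to compound 4 (within the scatter), that is, no change beyond the scatter. Compound 4 is expected to give about 100% in this assay, with a likely range from 90% to 100%.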

Compound 4, a percentage reported as activity, at one dose (the size of the read-out at that dose, not a potency): 100%
For compound 4 middle estimate and measured number coincide at the digits printed, within the range that was stated.
By their numbers in this assay, from the lowest: compounds 1, 2, 3 and 4 (each within the scatter of the next).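

In this assay, going by these compounds alone, putting hydrogen in place of fluoro on the aromatic carbon ortho to a carboxy group gives no change at the digits printed from compound 3 to compound 4 (within the scatter) and so provides the first direct reading of this position: with the carboxy and acetoxy groups kept, this fluoro group can go without a visible shift in the read-out at this one dose. A second one-place comparison, acetyl in place of methyl on an oxygen on the aromatic ring, gives no change at the digits printed from compound 1 to compound 4 (within the scatter) and shows that this change on the oxygen likewise leaves the read-out unmoved. No supporting measurement is available to explain either result.

Within the data shown here, these two steps do not show whether an amine or a longer chain on the same aromatic carbon would leave the read-out equally unmoved, since hydrogen and fluoro are the only groups compared there. Going by these compounds, it also remains open whether an amide in place of the carboxy group, or a longer acyl chain in place of the acetyl on the oxygen, would give a different reading in this assay.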